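The source may report more compounds than this note shows. Statements on the series, on what has been measured and on what is new or still open speak of the compounds shown alone.

Measured so far:
compound 1, `CC(C)c1cc(-c2n[nH]c(=O)n2-c2cccc(NC(=O)CCCCCCC(=O)NO)c2)c(O)cc1O`, gives 1600 nM in a functional assay on A549 cells (Homo sapiens) for inhibition; on this read-out higher numbers stand for weaker inhibition and lower numbers for stronger inhibition
compound 2, `CC(C)c1cc(-c2n[nH]c(=O)n2-c2cccc(NC(=O)CCCCC(=O)NO)c2)c(O)cc1O`, gives 1600 nM in this assay
compound 3, `CC(C)c1cc(-c2n[nH]c(=O)n2-c2ccc(C(=O)NCCCCCCCC(=O)NO)cc2)c(O)cc1O`, gives 4600 nM in this assay

Compound 1 and compound 2 share one core and differ by hydroxycarbamoyl in place of 2-(hydroxycarbamoyl)ethyl on a saturated chain carbon, four bonds along the chain from a carbonyl carbon; the step is no change at the digits printed from compound 1 to compound 2 (within the scatter). Compound 3 sits on another core; how the core of compound 1 and the core of compound 3 differ is not broken down here. Compound 3 gives the highest of the three numbers, beyond the scatter from both compound 1 and compound 2.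

Compound 4, `CC(C)c1cc(-c2n[nH]c(=O)n2-c2ccc(C(=O)NCCCCCC(=O)NO)cc2)c(O)cc1O`, is not yet measured. It differs from compound 3 by hydroxycarbamoyl in place of 2-(hydroxycarbamoyl)ethyl on a saturated chain carbon, five bonds along the chain from an amide-type nitrogen. This is the same kind of change as that between compound 1 and compound 2, not the same: there the place is on a saturated chain carbon, four bonds along the chain from a carbonyl carbon, here on a saturated chain carbon, five bonds along the chain from an amide-type nitrogen. The expectation rests on a single measured instance of this kind of change. The step from compound 3 to compound 4 is expected to be no change at the digits printed from compound 3 to compound 4 (within the scatter), within the scatter, because no change at the digits printed from compound 1 to compound 2 (within the scatter). Compound 4 is therefore expected near 4600 nM, between 2000 nM and 10000 nM.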

Compound 4, half-maximal inhibitory concentration: 4600 nM
For compound 4 middle estimate and measured number coincide at the digits printed, and the stated range covers the measured number.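

In this assay, hydroxycarbamoyl in place of 2-(hydroxycarbamoyl)ethyl on the core of compound 3 gives no change at the digits printed from compound 3 to compound 4 (within the scatter), and the change reads the same on the two cores: the same change on two cores in this assay, no change at the digits printed (within the scatter) from compound 1 to compound 2 and no change at the digits printed (within the scatter) from compound 3 to compound 4, 1.0-fold (0.00 log units) apart, within the scatter of two such steps. For these two pairs, then, the result for this change on the core of compound 1 also holds on the core of compound 3, with neither step beyond the scatter. Among the compounds shown here, this does not show that chain length is without effect in general, since the finding rests on two pairs in one assay and covers only this one change, so it cannot be extended to other chain lengths or to further cores.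

Still open, from the compounds shown here alone, is whether a longer chain on either core would stay as flat as these two steps. Also open, going by these compounds, is whether a carboxylic acid or an amine in place of the hydroxycarbamoyl end would give values like those seen in this assay.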